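The source may hold more compounds than are shown below. What is called first, only, known or untested is meant among the compounds shown, and "the series" means these compounds.

In an ADME assay on CEM-SS cells (Homo sapiens) for cytotoxicity, read by XTT assay (a lower number here means that less compound is tolerated, a higher number that more compound is tolerated), compound 1 (`O=C(NO)c1cc2ccn(Cc3ccc(F)cc3F)c2cn1`) gives > 320000 nM, and this value is a limit, not a number. Compound 2 (`N#Cc1cccc(Cn2ccc3cc(C(=O)NO)ncc32)c1`) gives > 10000 nM, which is also a limit. Within the data shown here, these two results provide no measured step between compounds, so any forecast has little to rest on.

Compound 3 (`NC(=O)c1cc(F)ccc1Cn1ccc2cc(C(=O)NO)ncc21`) has yet to be measured. Relative to compound 1, it has carbamoyl in place of fluoro on an aromatic carbon, ortho to a large group and meta to a fluoro group: carbamoyl in place of fluoro on an aromatic carbon. A moderate move towards lower numbers is expected in this assay, although the result may again be reported only as a limit. The estimated change is an at least 3.2-fold lower number from compound 1 to compound 3 (0.50 log units; beyond the scatter). Compound 3 is expected to give about 100000 nM, with an estimated range of 10000 nM to 320000 nM.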

Compound 3, half-maximal cytotoxic concentration: > 10000 nM
Compound 3 was reported as a limit; the forecaster's own chance of this, stated with the estimate: 75%; the middle value is on the limit's open side.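

Compound 1 and compound 3 are both reported only as limits in this assay, and the step between them cannot be read. The compounds shown leave open whether carbamoyl in place of fluoro on an aromatic carbon changes the cytotoxic concentration at all, and in which direction.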